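The source may report more compounds than this note shows. Statements on the series, on what has been measured and on what is new or still open speak of the compounds shown alone.

Measured compounds in a functional assay on MOLT-4 cells (Homo sapiens) for inhibition, read by sulforhodamine B assay, with a stated time of 48 h; a higher number here means that more compound is tolerated, a lower number that less compound is tolerated:
- Compound 1, `Nc1cc(N)c2nc(-c3ccccc3)c(Oc3ccc(Cl)c(Cl)c3)nc2c1`: in this assay compound 1 gives < 100000 nM, which is a limit of the assay and not a number.
- Compound 2, `CCOC(=O)[C@H](CCC(=O)O)NC(=O)c1ccc(Oc2nc3cc(N)cc(N)c3nc2-c2ccccc2)cc1`: in this assay compound 2 gives < 100000 nM, again a limit and not a number.

Compound 1 thus stands at the limit of < 100000 nM in this assay, at which 2 of the 2 values shown sit; nothing in the numbers separates compound 1 from compound 2, as both sit at the same limit.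

Compound 3, `Nc1cc(N)c2nc(-c3ccccc3)c(Sc3ccc(Cl)c(Cl)c3)nc2c1`, is not yet measured. It differs from compound 1 by (3,4-dichlorophenyl)sulfanyl in place of 3,4-dichlorophenoxy on an aromatic carbon.

Among the measured compounds shown here, no step between measured compounds is known, so there is no basis for a direction. The expected step from compound 1 to compound 3 in this assay is a step that the limit leaves unreadable from compound 1 to compound 3, that is, none beyond the scatter. For compound 3 the estimate in this assay is 50000 nM, with a range from 10000 nM to 100000 nM, and most likely only a limit will again be reported.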

Compound 3, concentration lethal to 50% of the cells: < 100000 nM
Compound 3: no number, only a limit; the forecaster's own chance of this, stated with the estimate: 70%; the middle value does not contradict the limit.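

In this assay, among the compounds shown here, compound 3 gives < 100000 nM, a limit and not a number, so no step from compound 1 to compound 3 can be read. The compounds shown leave open whether (3,4-dichlorophenyl)sulfanyl and 3,4-dichlorophenoxy differ at all in this read-out, since all values share one limit.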